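Lengthening the acetyl chain of compound 1

The compounds below may be only part of what the source reports. "The series", "measured", "known", "first", "only" and "open" are said of these compounds alone.

In an ADME assay on microsomes from liver (Homo sapiens) for metabolic stability, read by LC-MS, with NADPH named in the record, with a stated time of 60 min, tested at 1 uM, in the absence of a further agent (a higher number here means that more of the compound is left, a lower number that less of the compound is left), compound 1 (`COc1ccc(-c2c(C)nc3c(N4CC[C@@H](NC(C)=O)C4)cc(C)nn23)cc1OC`) gives > 95% as a limit of the assay, not a number. Compound 2 (`CC(=O)N[C@@H]1CCN(c2cc(C)nn3c(-c4ccc(C(F)(F)F)cc4)c(C)nc23)C1`) gives > 95% as a limit too. Compound 3 (`COc1ccc(-c2c(C)nc3c(N4CC[C@@H](NC(C)=O)C4)cc(C)nn23)cc1F`) likewise gives > 95% as a limit. The three therefore share one position (the limit of > 95% in this assay, at which 3 of the 3 values shown sit), and compound 1 has no readable rank among them.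

Compound 4 (`CCCCCC(=O)N[C@@H]1CCN(c2cc(C)nn3c(-c4ccc(OC)c(OC)c4)c(C)nc23)C1`) keeps the core of compound 1 and changes only the amide (butyl in place of hydrogen on a saturated chain carbon bound to a carbonyl carbon), which turns acetyl to pentylcarbonyl. The measured steps (a step that the two limits leave unreadable from compound 1 to compound 2), (a step that the two limits leave unreadable from compound 1 to compound 3) and (a step that the two limits leave unreadable from compound 2 to compound 3) all lie on an aromatic carbon, not on this chain, and none has a readable size. They therefore fix no size for the new change. With compound 1 at > 95% as a limit, any step that can be read is expected to lead toward less compound left. A step beyond the usual scatter is the expected case, though only a loose estimate can be offered. Estimated in this assay terms, the expected step is a number at least 23 percentage points lower from compound 1 to compound 4 (beyond the scatter) and its size remains uncertain. Compound 4 is expected at 72% (estimated range 40% to 95%).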

Compound 4, percent of the compound remaining: > 95%
Compound 4 ended at the assay's limit (the forecaster's own chance of this, stated with the estimate: 20%); middle value at least 23 percentage points from the limit.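

In this assay compound 4 gives > 95%, a limit of the assay and not a number. Compound 1 also stands at a limit, so the step between compound 1 and compound 4 cannot be read. All the compounds shown share one position: the limit of > 95% in this assay, at which 4 of the 4 values shown sit.

The compounds shown leave open whether any of these changes, on the chain or on an aromatic carbon, alters how much compound is left.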